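The source may report more compounds than this note shows. Statements on the series, on what has been measured and on what is new or still open speak of the compounds shown alone.

Compound 1 `CCCSc1nc(Cl)c2c(n1)N(CC1CCCCC1)C(C(=O)N1CCN(C)CC1)N2` gives 12800 nM in a functional assay on PC-3 cells (Homo sapiens) for antiproliferative activity, read by MTT assay, with a stated time of 72 h; on this read-out higher numbers stand for weaker inhibition and lower numbers for stronger inhibition. Compound 2 `CCCSc1nc(Cl)c2c(n1)N(Cc1ccccc1)C(C(=O)NCCNC(=O)OC(C)(C)C)N2` gives 29700 nM in this assay.

Of these two numbers, compound 1 holds the lower one, and the gap to compound 2 lies beyond the scatter. Compound 3 `CCCSc1nc(Cl)c2c(n1)N(CCNC(=O)OC(C)(C)C)C(C(=O)N1CCN(C)CC1)N2` differs from compound 1 in one place: ((tert-butoxycarbonyl)amino)methyl in place of cyclohexyl on a saturated chain carbon bound to a nitrogen on an aromatic ring in a ring. For the measured compounds named here, no measured pair isolates this change, so the comparison rests on compound 1 alone, with compound 2 as the only other point. The expected step in this assay is small and upward, if beyond the scatter at all: a 1.4-fold higher number from compound 1 to compound 3 (0.15 log units; within the scatter). Compound 3 is accordingly estimated at 18000 nM, with a range from 6000 nM to 60000 nM.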

Compound 3, half-maximal inhibitory concentration: > 64000 nM
Compound 3: only a limit was reported; the forecaster's own chance of this, stated with the estimate: 20%; middle value at least 3.5-fold (0.55 log units) away from the limit.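

Compound 3 carries a limit in this assay, not a number: the limit of > 64000 nM in this assay, at which 1 of the 3 values shown sits.

Compound 1 and compound 2 differ in more than one place, so neither could isolate this position. Here, on a saturated chain carbon bound to a nitrogen on an aromatic ring in a ring, ((tert-butoxycarbonyl)amino)methyl in place of cyclohexyl gives an at least 5.0-fold higher number from compound 1 to compound 3 (0.69 log units; beyond the scatter), so the position does not tolerate every substituent equally.

As far as these compounds go, whether this step follows the departure of the cyclohexyl ring or the arrival of the tert-butoxycarbonyl amino group stays open. A plain pentyl chain or a free 2-aminoethyl amine at this place would separate the two.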